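This account rests on a few compounds, and the source may have more. Where it says the series, first, only, none or still open, it means among the compounds named here.

Compound 1, `O=C(CN[C@H]1CCN(S(=O)(=O)Cc2ccccc2)C1)N1CCN(Cc2ccccc2Cl)CC1`, gives 9000 nM in a functional assay on K562 cells (Homo sapiens) for cytotoxicity, read by MTT assay, with a stated time of 48 h (a higher number here means a weaker inhibitor, a lower number a stronger inhibitor), the higher of the two numbers measured here. For the measured compounds named here, compound 2, `O=C(CN[C@H]1CCN(S(=O)(=O)Cc2ccccc2)C1)N1CCN(Cc2ccc(Cl)cc2Cl)CC1`, gives 4300 nM, and the one measured step, a 2.1-fold lower number from compound 1 to compound 2 (0.32 log units; beyond the scatter), shows a modest gain from a chloro in place of hydrogen on an aromatic carbon. Compound 3, `COc1cc(CN2CCN(C(=O)CN[C@H]3CCN(S(=O)(=O)Cc4ccccc4)C3)CC2)cc(OC)c1OC`, differs from compound 1 in a different way: 3,4,5-trimethoxyphenyl in place of 2-chlorophenyl on a saturated chain carbon bound to an amine nitrogen in a ring. Going by the values given here, no measured step exchanges the whole ring for one carrying three methoxy groups, so the chloro step is only a loose guide, and a change of this kind is expected to stay close to the scatter. Compound 3 is therefore estimated to give about 7000 nM, with a range from 2500 nM to 20000 nM. That estimate means a 1.3-fold lower number from compound 1 to compound 3 (0.11 log units; within the scatter), expected to be a small step.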

Compound 3, half-maximal inhibitory concentration: 93000 nM
Beside the measured number, compound 3's estimate is 13-fold (1.12 log units) below it; measured number outside the range, above it.
By their numbers in this assay, from the lowest: compound 2; then compound 1; then compound 3.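

In this assay, this position, on a saturated chain carbon bound to an amine nitrogen in a ring, turns out to respond far more strongly than the chloro step alone showed: the trimethoxy ring brings a 10-fold higher number from compound 1 to compound 3 (1.01 log units; beyond the scatter), and against the dichloro ring it brings a 22-fold higher number from compound 2 to compound 3 (1.34 log units; beyond the scatter). Both steps are large, so the aromatic ring at this position can shift the number considerably even though the rest of the molecule stays the same. The entering group has more heavy atoms and 3 hydrogen-bond acceptors where the leaving groups have none, but no measurement here explains the loss.

The compounds shown leave open whether a single methoxy group would act like three. From the compounds shown here alone, how a ring carrying fluoro or an amine would compare also remains unknown.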